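Fluoro to chloro on the sulfonyl ring: an expected step

A few compounds are considered here, and "the series" means these few. Any claim that something is new, unique, unknown or untested is made for them only; others in the source may bear on it.

Compound 1, `O=C1/C(=C/c2cccc(F)c2)CN(S(=O)(=O)c2ccc(F)cc2)C/C1=C\c1cccc(F)c1`, gives 5000 nM in a functional assay on HepG2 cells (Homo sapiens) for cytotoxicity, read by MTT assay, with a stated time of 24 h; a lower number here means a stronger inhibitor, a higher number a weaker inhibitor.
Compound 2, `O=C1/C(=C/c2cccc(F)c2)CN(S(=O)(=O)c2ccc(Cl)cc2)C/C1=C\c1cccc(F)c1`, gives 13100 nM in this assay.
Compound 3, `O=C1/C(=C/c2ccc(F)cc2)CN(S(=O)(=O)c2ccc(F)cc2)C/C1=C\c1ccc(F)cc1`, gives 8100 nM in this assay.

Of the compounds shown here, three have been measured so far; a fourth, compound 4, `O=C1/C(=C/c2ccc(F)cc2)CN(S(=O)(=O)c2ccc(Cl)cc2)C/C1=C\c1ccc(F)cc1`, has not. All four share a core in which two fluorinated aryl groups hang off a central ring that also carries an arylsulfonyl group, and the compounds differ only in the halogen on that sulfonyl ring and in where the fluorines sit on the other two rings.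

Between compound 1 and compound 2 the only difference is chloro in place of fluoro on an aromatic carbon, and in this assay this gave a 2.6-fold higher number from compound 1 to compound 2 (0.42 log units; beyond the scatter). Compound 3 differs from compound 1 in how the same atoms are joined; that difference between the two cores is not broken down here. Compound 3 stands near compound 2 and compound 1, and both of those gaps fall within the scatter of this assay, so no order among them can be claimed.

Compound 4 differs from compound 3 by chloro in place of fluoro on an aromatic carbon, the same change, in the same place, as from compound 1 to compound 2. Because that single earlier example gave a 2.6-fold higher number from compound 1 to compound 2 (0.42 log units; beyond the scatter), a similar step is expected here, though it rests on one pair only and the cores differ. The step expected in this assay from compound 3 to compound 4 is a 2.6-fold higher number from compound 3 to compound 4 (0.41 log units; beyond the scatter). Compound 4 is therefore estimated at 21000 nM, with a likely range from 9000 nM to 45000 nM.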

Compound 4, half-maximal inhibitory concentration: 4500 nM
Compound 4: the middle estimate sits 4.7-fold (0.67 log units) above what was measured; measured number outside the range, below it.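

Chloro in place of fluoro on the sulfonyl ring gave a 1.8-fold lower number from compound 3 to compound 4 (0.26 log units; within the scatter) in this assay, so on this core the swap leaves compound 3 and compound 4 indistinguishable in this measurement. Set beside the earlier step, the same swap did not behave alike on the two cores, which differ only in where the fluorines sit on the other two rings: the same change on two cores in this assay, a 2.6-fold higher number (0.42 log units; beyond the scatter) from compound 1 to compound 2 and a 1.8-fold lower number (0.26 log units; within the scatter) from compound 3 to compound 4, 4.7-fold (0.67 log units) apart, beyond the scatter of two such steps This shows that, within these four compounds, the result of the swap on the core of compound 1 cannot simply be carried over to the core of compound 3, but with only one pair on each core it does not explain the mismatch or predict what the swap would do on any further core.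

The sulfonyl ring here carries only fluoro or chloro, which leaves open how a methoxy group, a nitrile or an amine in that same place would read in this assay, and whether those results would also differ between the two cores. As far as these compounds go, the other two rings carry only fluorine as well, so the effect of a chloro group or a carboxylic acid on those rings also remains open.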